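Swapping Sulfamoyl for Methanesulfonamido: Expected Cytotoxicity

A few compounds are considered here, and "the series" means these few. Any claim that something is new, unique, unknown or untested is made for them only; others in the source may bear on it.

Measured so far in an ADME assay on BaF3 cells (Mus musculus) for cytotoxicity; on this read-out lower numbers stand for an effect already at smaller amounts and higher numbers for an effect only at larger amounts of compound:
Compound 1 `Nc1cccc(-c2cc(Nc3ccc(OC(F)(F)F)cc3)ncn2)c1` — > 10000 nM
Compound 2 `NS(=O)(=O)c1ccc(-c2cc(Nc3ccc(OC(F)(F)F)cc3)ncn2)cc1` — > 10000 nM

Both readings are limits of this assay rather than numbers. For compound 1 the reading > 10000 nM is such a limit. For compound 2 the reading > 10000 nM is likewise a limit, so compound 2 stands where every value shown so far stands, namely at the limit of > 10000 nM in this assay, at which 2 of the 2 values shown sit.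

Compound 3 `CS(=O)(=O)Nc1ccc(-c2cc(Nc3ccc(OC(F)(F)F)cc3)ncn2)cc1` has not yet been measured. It differs from compound 2 in one place: methanesulfonamido in place of sulfamoyl on an aromatic carbon. For the measured compounds named here, no step between two measured compounds is available, so nothing measured speaks to this exchange. As both measured compounds sit at the limit, compound 3 is expected to show no effect beyond the scatter either, giving an expected step that the limit leaves unreadable from compound 2 to compound 3. Compound 3 is thus estimated at 15000 nM, within 5000 nM to 50000 nM, most likely reported again as a limit.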

Compound 3, half-maximal effective concentration: 2210 nM
Compound 3: middle estimate off by 6.8-fold (0.83 log units), on the high side, and the stated range ends above it.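

In this assay, for the compounds shown here, putting methanesulfonamido in place of sulfamoyl on an aromatic carbon, para to a large group, gives an at least 4.5-fold lower number from compound 2 to compound 3 (0.65 log units; beyond the scatter), the first step that can be read. The position is therefore not indifferent to what it carries: the two groups match in their counts of hydrogen-bond donors and acceptors and in having no net charge, yet they do not behave alike here. The full size of the step remains unknown because the reading of compound 2 is a limit: the limit of > 10000 nM in this assay, at which 2 of the 3 values shown sit.

The compounds shown leave open whether the gain follows from the added methyl or from the nitrogen now standing on the ring. They also leave open how an acetamide, a carboxylic acid or a longer chain such as ethanesulfonamido would read at this place.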